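The compounds below may be only part of what the source reports. "The series", "measured", "known", "first", "only" and "open" are said of these compounds alone.

Going by the values given here, in an ADME assay on A549 cells (Homo sapiens) for cytotoxicity, read by resazurin assay, with a stated time of 48 h (on this read-out higher numbers stand for lower toxicity in this test and lower numbers for higher toxicity in this test), compound 1 `COc1ccc(CNc2ccc(NC(=O)c3cc(Cl)ccc3O)c(Cl)c2)cc1` gives 80700 nM and compound 2 `O=C(Nc1ccc(NCc2cnccc2Cl)cc1Cl)c1cc(Cl)ccc1O` gives 126000 nM, so compound 2 stands level with the only other measured compound. Compound 3 `CC(C)(CCO)Nc1ccc(NC(=O)c2cc(Cl)ccc2O)c(Cl)c1` carries 3-hydroxy-1,1-dimethylpropyl in place of (4-chloropyridin-3-yl)methyl on a nitrogen on an aromatic ring. Among the compounds with values here, the sole measured step bearing on this, a 1.6-fold higher number from compound 1 to compound 2 (0.19 log units; within the scatter), exchanged one ring for another and stayed within the scatter. Within the data shown here, no measured compound lacks a ring there, so the evidence is thin. In this assay no step beyond the scatter is expected, and the expected change is a 1.5-fold lower number from compound 2 to compound 3 (0.17 log units; within the scatter). Compound 3 is estimated at 85000 nM, within a range of 35000 nM to 200000 nM.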

Compound 3, half-maximal cytotoxic concentration: 170000 nM
Beside the measured number, compound 3's estimate is 2.0-fold (0.30 log units) below it; measured number inside the range.
By their numbers in this assay, from the lowest: compounds 1, 2 and 3 (each within the scatter of the next, the first and the last beyond it).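

In this assay, a chain with no ring, 3-hydroxy-1,1-dimethylpropyl, can stand on this nitrogen in place of (4-chloropyridin-3-yl)methyl, with a 1.3-fold higher number from compound 2 to compound 3 (0.13 log units; within the scatter). Going by these compounds alone, in place of 4-methoxybenzyl, the same chain gives a 2.1-fold higher number from compound 1 to compound 3 (0.32 log units; beyond the scatter), the first step at this position beyond the scatter, though a modest one. Nothing on hand accounts for either step. As far as these compounds go, it remains open whether the hydroxyl of the chain matters, as 1,1-dimethylpropyl would show, and how a carboxylic acid or a longer chain on this nitrogen would read.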